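Furan-2-yl to furan-3-yl swap on two related cores

A few compounds are considered here, and "the series" means these few. Any claim that something is new, unique, unknown or untested is made for them only; others in the source may bear on it.

Compound 1 `CC1=C(C(=O)OCC(C)C)C(c2ccco2)NC(=S)N1` gives 10% in an assay on membranes from HeLa cells for displacement of a labelled ligand from adenosine receptor A3 (Homo sapiens), read by scintillation counting, with a stated time of 180 min, tested at 1 uM; on this read-out lower numbers stand for less inhibition and higher numbers for more inhibition at the one concentration tested (going by the name of the read-out). Compound 2 `CC1=C(C(=O)OCC(C)C)C(c2ccoc2)NC(=S)N1` differs from it by furan-3-yl in place of furan-2-yl on a saturated ring carbon and gives 1% in this assay; the step of a number 9 percentage points lower from compound 1 to compound 2 (within the scatter) is within the scatter, so the two numbers are taken as level. Compound 3 `CCC(CC)OC(=O)C1=C(C)NC(=O)NC1c1ccco1` carries a different core; how the two cores differ is not broken down here. In this assay compound 3 gives 1%, which is level with compound 2 at the digits shown and within the scatter of compound 1. Compound 4 `CCC(CC)OC(=O)C1=C(C)NC(=O)NC1c1ccoc1` is compound 3 with furan-3-yl in place of furan-2-yl on a saturated ring carbon. This is the same kind of change as that from compound 1 to compound 2, though the surroundings differ: in compound 3 the saturated ring carbon sits next to the ring atom that bears a group of 8 heavy atoms, whereas in compound 1 that ring atom bears a group of 7 heavy atoms. The step from compound 3 to compound 4 is expected to be about no change at the digits printed from compound 3 to compound 4 (within the scatter), resting on the earlier step of a number 9 percentage points lower from compound 1 to compound 2 (within the scatter), which stayed within the scatter, and on the low starting value of compound 3 1%. Compound 4 is therefore estimated at 1%, between -6% and 10%.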

Compound 4, a percentage reported as inhibition, at one concentration (the size of the read-out at that concentration, not a potency): 5%
Compound 4: the middle estimate sits 4 percentage points below what was measured; measured number inside the range.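

In this assay, furan-3-yl in place of furan-2-yl on a saturated ring carbon gives a number 4 percentage points higher from compound 3 to compound 4 (within the scatter), and the comparison with the earlier swap finds no difference between the two cores: the same change on two cores in this assay, a number 9 percentage points lower (within the scatter) from compound 1 to compound 2 and a number 4 percentage points higher (within the scatter) from compound 3 to compound 4, 13 percentage points apart, within the scatter of two such steps This shows that, on these two cores, the swap leaves the read-out level at the one concentration tested, and the two steps agree as far as the scatter allows. It does not show that the change carries a real effect from one core to the other, since neither step stands clear of the scatter, and a single-concentration read-out gives no potency.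

Still open, on these data alone, is whether an amine or a carboxylic acid in place of the furan on the saturated ring carbon would move the read-out beyond the scatter. Also open, as far as these compounds go, is how the furan swap behaves on a core that starts from a clearly higher number, where a step in either direction could be read.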